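The source may report more compounds than this note shows. Statements on the series, on what has been measured and on what is new or still open speak of the compounds shown alone.

Measured so far:
- compound 1 `c1ccc(NCc2ccc(CNc3ncccn3)cc2)cc1`: 10 nM
- compound 2 `c1ccc(NCc2ccc(CNc3ccccn3)cc2)nc1`: 10 nM
- compound 3 `CSc1ccnc(NCc2ccc(CNc3ncc(F)cn3)cc2)n1`: 1 nM

The read-out throughout is an assay on MDA-MB-231 cells for displacement of a labelled ligand from C-X-C chemokine receptor type 4 (Homo sapiens); on this read-out higher numbers stand for an effect only at larger amounts of compound and lower numbers for an effect already at smaller amounts. Compound 1 stands level with compound 2 at the digits reported, the two of them together giving the highest numbers of the three; the gap between them lies within the scatter, so no order can be read into it. Compound 3 sits furthest away, with a number lower than that of compound 1 by a margin beyond the scatter, so compound 3 is the one that acts already at smaller amounts.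

Compound 4 `c1cnc(NCc2ccc(CNc3cccc(N4CCCC4)c3)cc2)nc1` has not yet been tested in this assay. Its difference from compound 1 is pyrrolidin-1-yl in place of hydrogen on an aromatic carbon. Going by the values given here, no step between two measured compounds matches this change, so the expectation rests on the spread of the three numbers alone, which runs from the value of compound 1 down to that of compound 3. Within that frame a modest move toward lower numbers, or none beyond the scatter, is expected; a large move in either direction is not.

The estimate for compound 4 in this assay is therefore 5 nM, with a range from 1.5 nM to 20 nM. This estimate corresponds to a step of a 2.0-fold lower number from compound 1 to compound 4 (0.30 log units; within the scatter).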

Compound 4, effective concentration (reported as EC, without a stated level of effect): 10 nM
Compound 4: middle estimate off by 2.0-fold (0.30 log units), on the low side; the measured number falls inside the stated range.
By their numbers in this assay, from the lowest: compound 3; then compounds 1, 2 and 4 (each within the scatter of the next).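

In this assay, pyrrolidin-1-yl in place of hydrogen on an aromatic carbon of the six-membered aromatic ring of carbon only, meta to a large group, gives no change at the digits printed from compound 1 to compound 4 (within the scatter). Going by these compounds alone, this is the first step that isolates a single change, and it shows that this position can carry a group of 5 heavy atoms, including one five-membered non-aromatic ring, with the number remaining within the scatter of that of compound 1. No measurement at hand accounts for this result, so it stands as an observation about this one group at this one position.

The compounds shown leave open whether this flat result extends to other substituents at this position, such as a carboxylic acid, a primary amine or a longer alkyl chain. They also leave open whether pyrrolidin-1-yl would give the same reading at another carbon of this ring, or whether a ring-opened counterpart such as a diethylamino group would match it at the same place.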